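Trifluoromethyl on the aryl ring: pyrrolidine versus pyrrole acids

The compounds below may be only part of what the source reports. "The series", "measured", "known", "first", "only" and "open" are said of these compounds alone.

Compound 1 `O=C(O)C1CCN(c2ccccc2)C1` is the weakest of the three measured compounds; in an assay on cells for inhibition of Palmitoleoyl-protein carboxylesterase NOTUM variant C330S (Homo sapiens), read by fluorescence, with a stated time of 40 min (on this read-out lower numbers stand for stronger inhibition and higher numbers for weaker inhibition), compound 1 gives 48000 nM. Compound 3 `Cc1cc(C(=O)O)c(C)n1-c1ccc(Cl)cc1` gives 860 nM and compound 2 `Cc1cc(C(=O)O)c(C)n1-c1ccc(Cl)c(C(F)(F)F)c1` gives 2100 nM. The difference between the core of compound 1 and the core of compound 3 is not broken down here. From compound 3 to compound 2 the change is trifluoromethyl in place of hydrogen on an aromatic carbon, and the step is a 2.4-fold higher number from compound 3 to compound 2 (0.39 log units; beyond the scatter). Compound 4 `O=C(O)C1CCN(c2ccc(C(F)(F)F)cc2)C1` carries the same kind of change against compound 1, namely (trifluoromethyl in place of hydrogen on an aromatic carbon), but the surroundings differ: in compound 2 the new group is ortho to a chloro group and meta to a large group, whereas in compound 4 it is para to a group of 8 heavy atoms. For compound 4 a step of a 1.5-fold higher number from compound 1 to compound 4 (0.16 log units; within the scatter) is expected, beside the earlier 2.4-fold higher number from compound 3 to compound 2 (0.39 log units; beyond the scatter), resting on that single precedent. Compound 4 is therefore estimated at 70000 nM, between 15000 nM and 250000 nM.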

Compound 4, half-maximal inhibitory concentration: 50000 nM
Compound 4: the middle estimate sits 1.4-fold (0.15 log units) above what was measured; the range from low to high includes it.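

In this assay the new step is a 1.0-fold higher number from compound 1 to compound 4 (0.02 log units; within the scatter), so trifluoromethyl in place of hydrogen on an aromatic carbon leaves compound 4 level with compound 1. Set beside the step on the other core, this result does not separate the two cores: the same change on two cores in this assay, a 2.4-fold higher number (0.39 log units; beyond the scatter) from compound 3 to compound 2 and a 1.0-fold higher number (0.02 log units; within the scatter) from compound 1 to compound 4, 2.3-fold (0.37 log units) apart, within the scatter of two such steps. This is consistent with the change carrying across these two cores, but it rests on one pair per core with the new group in different surroundings, so it does not establish a general rule for the series.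

Still open, from the compounds shown here alone, is how a nitrile or a methoxy group in place of the same hydrogen would behave on the core of compound 1. Also open, going by these compounds, is whether trifluoromethyl elsewhere on that aromatic ring would give a similar step.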